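The source may hold more compounds than are shown below. What is called first, only, known or untested is meant among the compounds shown, and "the series" means these compounds.

Compound 2, built as `COc1ccccc1C(C1=C(O)C(=O)c2ccccc2C1=O)c1c[nH]c2ccccc12`, is one of two compounds for which a value is known in a functional assay on HeLa cells (Homo sapiens) for cytotoxicity, read by MTT assay, with a stated time of 48 h; a lower number here means a stronger inhibitor, a higher number a weaker inhibitor. Compound 2 gives 128000 nM, the higher of the two numbers. The other compound, compound 1, has the structure `COc1cc(C(C2=C(O)C(=O)c3ccccc3C2=O)c2c[nH]c3ccc(Br)cc23)cc(OC)c1OC`; in this assay compound 1 gives 9710 nM. For the measured compounds named here, the gap between these two lies beyond the usual scatter, but the two structures differ in several places at once, so the comparison says only that compound 2 sits at the weaker end of what has been seen.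

Compound 3, `COc1cccc(C(C2=C(O)C(=O)c3ccccc3C2=O)c2c[nH]c3ccccc23)c1`, is the unmeasured neighbour of compound 2. The change is 3-methoxyphenyl in place of 2-methoxyphenyl on a saturated chain carbon bound to an aromatic carbon and a double-bonded ring carbon. The methoxy group keeps its ring and its count of atoms, donors and acceptors; only its position on that ring moves. Going by the values given here, no step of this kind has been measured here, so the direction is open. Among the compounds with values here, because compound 1, the only other number, gives 9710 nM with a lower value, a modest shift toward a lower number is a reasonable guess, though a change within the scatter is just as plausible. The step from compound 2 to compound 3 is estimated at a 1.6-fold lower number from compound 2 to compound 3 (0.20 log units; within the scatter). Compound 3 is therefore expected to give 80000 nM, within a range from 20000 nM to 300000 nM.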

Compound 3, half-maximal inhibitory concentration: 25600 nM
Compound 3: the middle estimate sits 3.1-fold (0.49 log units) above what was measured; the measured number falls inside the stated range.
By their numbers in this assay, from the lowest: compound 1; then compound 3; then compound 2.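

Moving the methoxy group from 2-methoxyphenyl to 3-methoxyphenyl, on a saturated chain carbon bound to an aromatic carbon and a double-bonded ring carbon, gives a 5.0-fold lower number from compound 2 to compound 3 (0.70 log units; beyond the scatter) in this assay, the first comparison here in which only one place differs. It shows that activity at this position responds to where the methoxy group sits on its ring, even with the heavy atoms and the counts of donors and acceptors unchanged, something the pair of compound 1 and compound 2 could not show with their several differences. No measurement at hand bears on the origin of this step, so it stands as an observation only.

The compounds shown leave open whether an amine, a carboxylic acid or a longer chain such as ethoxy, placed on the ring in the methoxy group's stead, would continue the step or reverse it. They also leave open whether moving the methoxy group would have a similar effect on the core of compound 1, which carries bromine and further methoxy groups.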